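From an Amide to a Urea on the Shared Core

The compounds below may be only part of what the source reports. "The series", "measured", "known", "first", "only" and "open" are said of these compounds alone.

Measured so far in a functional assay on UO-31 cells (Homo sapiens) for inhibition, read by sulforhodamine B assay, with a stated time of 48 h; a higher number here means a weaker inhibitor of growth, a lower number a stronger inhibitor of growth:
Compound 1, `O=C(Nc1cccc(-n2cc(-c3ccncc3)c(-c3ccc(Cl)c(O)c3)n2)c1)Nc1ccc(Cl)c(Cl)c1`, gives > 32500 nM, which is a limit of the assay and not a number.
Compound 2, `COc1cc(-c2nn(-c3cccc(NC(=O)c4ccc(Cl)c(C(F)(F)F)c4)c3)cc2-c2ccncc2)ccc1Cl`, gives > 32500 nM, again a limit rather than a number.
Compound 3, `O=C(Nc1cccc(-n2cc(-c3ccncc3)c(-c3ccc(Cl)c(O)c3)n2)c1)Nc1cc(C(F)(F)F)cc(C(F)(F)F)c1`, gives 1900 nM.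

Compound 2 therefore stands at the edge of what this assay can report, and it shares that place with one other compound, as the limit of > 32500 nM in this assay, at which 2 of the 3 values shown sit, shows; only compound 3 has a measured number among the three.

Compound 4, `COc1cc(-c2nn(-c3cccc(NC(=O)Nc4cccc(C(F)(F)F)c4)c3)cc2-c2ccncc2)ccc1Cl`, has not yet been measured. It differs from compound 2 in one place: (3-(trifluoromethyl)phenyl)amino in place of 4-chloro-3-(trifluoromethyl)phenyl on a carbonyl carbon. The carbonyl carbon, whose other neighbour is an amide-type nitrogen, thus carries an amino-linked aryl group, turning the amide of compound 2 into a urea.

Among the measured compounds shown here, no measured pair differs in only one place, so there is no directly comparable step. For the measured compounds named here, compound 3, a urea, is the one compound with a number, while compound 1, also a urea, sits at the limit, so the urea linkage alone does not decide the outcome. A modest improvement is expected, and the step of an at least 2.1-fold lower number from compound 2 to compound 4 (0.33 log units; beyond the scatter) is the estimate that follows. For compound 4 the expected value in this assay is 15000 nM, with a plausible range from 3000 nM to 40000 nM.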

Compound 4, concentration for total growth inhibition: 3210 nM
For compound 4 the middle estimate is 4.7-fold (0.67 log units) above the measured one, and the stated range covers the measured number.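

Among the compounds shown here, the exchange of 4-chloro-3-(trifluoromethyl)phenyl for (3-(trifluoromethyl)phenyl)amino on a carbonyl carbon gives an at least 10-fold lower number from compound 2 to compound 4 (1.00 log units; beyond the scatter) in this assay, the first step here between two compounds that differ in one place, and it shows that this position can move the read-out from the edge of the assay to a measured number. The lower end of that step is all that can be stated, since compound 2 gives > 32500 nM, which is a limit of the assay and not a number: the limit of > 32500 nM in this assay, at which 2 of the 4 values shown sit. The change is also a double one at a single place, for the entering group brings an amino nitrogen with 1 hydrogen-bond donor and has no chlorine, while the leaving group has that chlorine and no donor, so the step cannot assign the gain to either difference.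

The compounds shown leave open whether the amino nitrogen alone carries the step, which a urea keeping the 4-chloro-3-(trifluoromethyl)phenyl group would help to separate. They also leave open what a methylene or an ether oxygen would do in place of that amino nitrogen on the carbonyl carbon.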